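A few compounds are considered here, and "the series" means these few. Any claim that something is new, unique, unknown or untested is made for them only; others in the source may bear on it.

Compound 3 `O=C(/C=C/c1cn(-c2ccccc2)nc1-c1cccnc1)c1ccccc1` stands in a functional assay on Huh-7 cells (Homo sapiens) for inhibition, read by sulforhodamine B assay, with a stated time of 72 h (on this read-out higher numbers stand for weaker inhibition and lower numbers for stronger inhibition), at 2300 nM, the second highest of the three numbers recorded so far; compound 1 `O=C(/C=C/c1cn(-c2ccccc2)nc1-c1cccnc1)c1ccsc1` gives 1700 nM and compound 2 `O=C(/C=C/c1cn(-c2ccccc2)nc1-c1cccnc1)c1ccccn1` gives 6400 nM. The step of a 1.4-fold higher number from compound 1 to compound 3 (0.13 log units; within the scatter) lies within the scatter, whereas a 2.8-fold lower number from compound 2 to compound 3 (0.44 log units; beyond the scatter) goes beyond it. Compound 4 `COc1ccc(C(=O)/C=C/c2cn(-c3ccccc3)nc2-c2cccnc2)cc1OC` differs from compound 3 at the same carbonyl carbon: 3,4-dimethoxyphenyl in place of phenyl on a carbonyl carbon. Both earlier steps exchanged one aryl group for another on this carbon, and only the move to pyridin-2-yl produced a change beyond the scatter. For the measured compounds named here, no measured compound carries a 3,4-dimethoxyphenyl group, so the change is not directly covered. Compound 4 is therefore expected to shift by a 1.2-fold lower number from compound 3 to compound 4 (0.06 log units; within the scatter), a step within the scatter. The estimate for compound 4 is 2000 nM, ranging from 700 nM to 6000 nM.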

Compound 4, half-maximal inhibitory concentration: 3100 nM
For compound 4 the middle estimate is 1.6-fold (0.19 log units) below the measured one; measured number inside the range.
By their numbers in this assay, from the lowest: compounds 1, 3 and 4 (each within the scatter of the next); then compound 2.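

Placing 3,4-dimethoxyphenyl on the carbonyl carbon leaves the read-out within the scatter of the smaller aryl groups, with a 1.3-fold higher number from compound 3 to compound 4 (0.13 log units; within the scatter) and a 1.8-fold higher number from compound 1 to compound 4 (0.26 log units; within the scatter), so this carbon accepts the two added methoxy groups without a change that can be read. The pyridin-2-yl group still stands apart, with a 2.1-fold lower number from compound 2 to compound 4 (0.31 log units; beyond the scatter), which leaves compound 2 as the only one of the four separated from the rest. Nothing available explains this behaviour at the carbonyl carbon. The compounds shown leave open whether a single methoxy group would behave like the pair. They also leave open whether an amine or a carboxylic acid on the phenyl ring would stay within this range.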